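Aryl in place of alkynyl on the five-membered ring

A few compounds are considered here, and "the series" means these few. Any claim that something is new, unique, unknown or untested is made for them only; others in the source may bear on it.

Measured so far in a functional assay on HL-60 cells (Homo sapiens) for antiproliferative activity, with a stated time of 72 h; on this read-out higher numbers stand for weaker inhibition and lower numbers for stronger inhibition:
- compound 1, `CCCC#Cc1cc([C@@H]2O[C@H](CO)[C@@H](O)[C@H]2O)n2ncnc(N)c12`: 200 nM
- compound 2, `CCCCC#Cc1cc([C@@H]2O[C@H](CO)[C@@H](O)[C@H]2O)n2ncnc(N)c12`: 400 nM
- compound 3, `Nc1ncnn2c([C@@H]3O[C@H](CO)[C@@H](O)[C@H]3O)cc(C#Cc3ccc(F)cc3)c12`: > 100000 nM, which is a limit of the assay and not a number.

Compound 2 holds the higher of the two numbers; its nearest neighbour is compound 1, with a 2.0-fold higher number from compound 1 to compound 2 (0.30 log units; within the scatter), a gap within the scatter. The third entry, compound 3, sits at the limit of > 100000 nM in this assay, at which 1 of the 3 values shown sits.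

Compound 4, `COc1ccc(-c2cc([C@@H]3O[C@H](CO)[C@@H](O)[C@H]3O)n3ncnc(N)c23)cc1`, differs from compound 2 by 4-methoxyphenyl in place of hex-1-yn-1-yl on an aromatic carbon. Among the measured compounds shown here, two measured steps bear on it, both putting an aryl ring where the alkyl part of the alkyne had been: an at least 500-fold higher number from compound 1 to compound 3 (2.69 log units; beyond the scatter) and an at least 250-fold higher number from compound 2 to compound 3 (2.39 log units; beyond the scatter). For the measured compounds named here, in compound 4 the triple bond itself is gone as well, so the change goes further than compound 3 tested, and no measured compound carries an aryl directly on that ring carbon. Both aryl steps ended at the limit, so a large rise in number is expected for compound 4, a 100-fold higher number from compound 2 to compound 4 (2.00 log units; beyond the scatter), with a real chance that only a limit is returned. Compound 4 is therefore estimated at 40000 nM, in the range 4000 nM to 150000 nM.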

Compound 4, half-maximal inhibitory concentration: > 100000 nM
Compound 4: a limit, no number (the forecaster's own chance of this, stated with the estimate: 40%); at least 2.5-fold (0.39 log units) between middle value and limit.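

In this assay compound 4 gives > 100000 nM, a limit of the assay and not a number. With 4-methoxyphenyl set directly on this aromatic carbon and no triple bond left, the readable steps are an at least 250-fold higher number from compound 2 to compound 4 (2.39 log units; beyond the scatter) and an at least 500-fold higher number from compound 1 to compound 4 (2.69 log units; beyond the scatter), so the loss seen with compound 3 is not confined to an aryl carried on the alkyne. The step from compound 3 to compound 4 cannot be read, and the two aryl compounds stand together at one value: the limit of > 100000 nM in this assay, at which 2 of the 4 values shown sit.

On these data alone, whether a saturated hexyl chain on this carbon would hold the level of compound 2 stays open, so loss of the triple bond and entry of the aryl ring remain unseparated. Also open, as far as these compounds go, is how a small group such as an amine would fare at this position.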